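Amide aryl variation on the hydroxyflavone core: compound 3

The source may report more compounds than this note shows. Statements on the series, on what has been measured and on what is new or still open speak of the compounds shown alone.

Within the data shown here, compound 2 `COc1ccc(C(=O)Nc2cccc(-c3oc4cc(-c5ccc(F)cc5)ccc4c(=O)c3O)c2)c(F)c1` stands at the higher end of the two numbers so far: in a functional assay on HeLa cells (Homo sapiens) for antiproliferative activity, read by CCK-8 assay, with a stated time of 72 h (on this read-out lower numbers stand for stronger inhibition and higher numbers for weaker inhibition), compound 2 gives 16100 nM, while compound 1 `Cc1ccc(C(=O)Nc2cccc(-c3oc4cc(-c5ccc(F)cc5)ccc4c(=O)c3O)c2)cc1` gives 6190 nM. Among the measured compounds shown here, the one measured step runs across the same position that compound 3 changes: a 2.6-fold higher number from compound 1 to compound 2 (0.42 log units; beyond the scatter). Compound 3 `N#Cc1ccc(C(=O)Nc2cccc(-c3oc4cc(-c5ccc(F)cc5)ccc4c(=O)c3O)c2)cc1` differs from compound 2 by 4-cyanophenyl in place of 2-fluoro-4-methoxyphenyl on a carbonyl carbon. For the measured compounds named here, the only step that bears on this change is the one from compound 1 to compound 2, a modest rise when the 4-methylphenyl became the 2-fluoro-4-methoxyphenyl. Compound 3 returns to a singly substituted phenyl on the carbonyl carbon, as in compound 1, so a number closer to that of compound 1 is the working expectation, with the 4-cyanophenyl untested anywhere in the series. A modest fall in this assay, about the size of the measured step, is expected: a 2.0-fold lower number from compound 2 to compound 3 (0.30 log units; within the scatter). Compound 3 is therefore estimated at 8000 nM in this assay, with a range from 3000 nM to 22000 nM.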

Compound 3, half-maximal inhibitory concentration: 23300 nM
Beside the measured number, compound 3's estimate is 2.9-fold (0.46 log units) below it; measured number above the stated range.
By their numbers in this assay, from the lowest: compound 1; then compounds 2 and 3 (each within the scatter of the next).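

In this assay, 4-cyanophenyl in place of 2-fluoro-4-methoxyphenyl on the carbonyl carbon gives a 1.4-fold higher number from compound 2 to compound 3 (0.16 log units; within the scatter), so these two groups are not told apart here, and a singly substituted phenyl on that carbon does not in itself go with a number like that of compound 1. The cleaner comparison is cyano in place of methyl on an aromatic carbon, which gives a 3.8-fold higher number from compound 1 to compound 3 (0.58 log units; beyond the scatter); with a 2.6-fold higher number from compound 1 to compound 2 (0.42 log units; beyond the scatter) also beyond the scatter, compound 1 is the strongest of the three, and its 4-methylphenyl is the only group shown here that stands apart at this position. No measured evidence accompanies these numbers to account for the difference between methyl and cyano.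

From the compounds shown here alone, whether that standing belongs to methyl in particular remains open: an unsubstituted phenyl, a 4-ethylphenyl, a 4-aminophenyl or a 4-carboxyphenyl on the carbonyl carbon could each fall with compound 1 or with compounds 2 and 3. How much of the number of compound 2 goes with the fluoro and how much with the methoxy also stays unresolved.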